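Sulfonyl replacement on the amine nitrogen of a cytotoxic core

This account rests on a few compounds, and the source may have more. Where it says the series, first, only, none or still open, it means among the compounds named here.

The measured compounds and their values in a functional assay on Ehrlich cells (Mus musculus) for cytotoxicity, read by trypan blue exclusion, with a stated time of 2 h (on this read-out higher numbers stand for weaker inhibition and lower numbers for stronger inhibition), are:
compound 1 `N#CC1=C(N)N(c2ccc(S(N)(=O)=O)cc2)C2=C(C(=O)CCC2)C1c1ccc(Cl)cc1Cl`: 25 ug/mL
compound 2 `N#CC1=C(NC(=S)Nc2ccccc2)N(c2ccc(S(N)(=O)=O)cc2)C2=C(C(=O)CCC2)C1c1ccc(Cl)cc1Cl`: 25 ug/mL
compound 3 `N#CC1=C(NC(N)=O)N(c2ccc(S(N)(=O)=O)cc2)C2=C(C(=O)CCC2)C1c1ccc(Cl)cc1Cl`: 75 ug/mL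

Compound 3 stands highest of the three numbers in this assay; its nearest neighbour is compound 1, with a 3.0-fold higher number from compound 1 to compound 3 (0.48 log units; beyond the scatter), and the step of a 3.0-fold higher number from compound 2 to compound 3 (0.48 log units; beyond the scatter) is of the same size.

Compound 4 `N#CC1=C(NS(=O)(=O)c2ccc(Br)cc2)N(c2ccc(S(N)(=O)=O)cc2)C2=C(C(=O)CCC2)C1c1ccc(Cl)cc1Cl` differs from compound 3 by (4-bromophenyl)sulfonyl in place of carbamoyl on an amine nitrogen. Going by the values given here, two measured steps bear on this. The step from an unsubstituted amine nitrogen to a group carrying a six-membered aromatic ring gave no change at the digits printed from compound 1 to compound 2 (within the scatter), whereas the step from that aryl-bearing group to carbamoyl gave a 3.0-fold higher number from compound 2 to compound 3 (0.48 log units; beyond the scatter). Removing carbamoyl and putting a ring-bearing group in its place therefore is expected to give a modest decrease in the number, roughly reversing that earlier step: a 2.5-fold lower number from compound 3 to compound 4 (0.40 log units; beyond the scatter). Compound 4 is estimated at 30 ug/mL, within a range of 12 ug/mL to 80 ug/mL.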

Compound 4, half-maximal inhibitory concentration: 5.5 ug/mL
Beside the measured number, compound 4's estimate is 5.5-fold (0.74 log units) above it; the measured number lies below the stated range.
By their numbers in this assay, from the lowest: compound 4; then compounds 1 and 2 (each within the scatter of the next); then compound 3.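

In this assay the amine nitrogen now shows a substituent that takes the number below that of the free amine (a 4.5-fold lower number from compound 1 to compound 4 (0.66 log units; beyond the scatter)), whereas the earlier groups on this nitrogen left it unchanged or raised it. Two groups that each carry a six-membered aromatic ring also differ here (a 4.5-fold lower number from compound 2 to compound 4 (0.66 log units; beyond the scatter)), so the presence of such a ring does not by itself set the number, and the step from the ureido compound is the largest seen at this position (a 14-fold lower number from compound 3 to compound 4 (1.13 log units; beyond the scatter)). Nothing given here accounts for these differences. The compounds shown leave open whether the sulfonyl link or the bromine carries the change. A plain phenylsulfonyl or a methanesulfonyl group on this nitrogen would separate the two.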